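The compounds below may be only part of what the source reports. "The series", "measured", "known", "first", "only" and "open" are said of these compounds alone.

Compound 1 `COc1ccc(-c2ccc3c(c2)CCC3=O)cc1F` and compound 2 `CCc1cc(-c2ccc3c(c2)CCCC3=O)ccc1OC` have both been tested in an assay on T47D cells for inhibition of 17-beta-hydroxysteroid dehydrogenase type 1 (Homo sapiens), with a stated time of 30 min, tested at 10 uM; on this read-out lower numbers stand for less inhibition and higher numbers for more inhibition at the one concentration tested (going by the name of the read-out). In that assay compound 1 gives 56%, while compound 2 gives 71%. Of these two numbers, compound 1 stands lower, and its distance to compound 2 is wider than the usual scatter of repeated measurements, so compound 2 shows more inhibition at the single concentration used.

Compound 3 `O=C1CCc2cc(-c3ccc(O)c(F)c3)ccc21` has not yet been measured. It differs from compound 1 in one place only: hydrogen in place of methyl on an oxygen on an aromatic ring. Cut one bond further out, the change reads methoxy to hydroxy. Among the measured compounds shown here, no pair of measured compounds shares this change, so the data give no direct guide to its size or direction.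

In this assay a modest rise in inhibition is expected, with a step of about a number 12 percentage points higher from compound 1 to compound 3 (beyond the scatter), although an outcome within the scatter cannot be ruled out. Compound 3 is therefore estimated to give 68%, with a likely range from 45% to 88%.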

Compound 3, a percentage reported as inhibition, at one concentration (the size of the read-out at that concentration, not a potency): 75%
For compound 3 the middle estimate is 7 percentage points below the measured one; low and high end bracket the measured number.
By their numbers in this assay, from the lowest: compound 1; then compounds 2 and 3 (each within the scatter of the next).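

In this assay, the change from methoxy to hydroxy comes with a number 19 percentage points higher from compound 1 to compound 3 (beyond the scatter). Among the compounds shown here, this is the first measured pair that differs in one place only, and it shows that the group on this oxygen on an aromatic ring matters for the read-out: taking away a single methyl and leaving a hydrogen is enough to shift the number, and the shift is toward more inhibition, not less. Nothing among the data shown accounts for why the number rises with this change.

As far as these compounds go, this is a single pair on a single core, read at one concentration, so it remains open whether the same change would go the same way on the core of compound 2, and whether the step reflects a real change in potency. Also open, from the compounds shown here alone, is how far the position can be pushed in either direction, for example with a longer chain on the oxygen such as ethoxy, or with an amine or a carboxylic acid in place of the hydroxy.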